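The source may report more compounds than this note shows. Statements on the series, on what has been measured and on what is new or still open speak of the compounds shown alone.

Measured in an ADME assay on Caco-2 cells (Homo sapiens) for permeability, in the apical to basolateral direction; on this read-out lower numbers stand for lower permeability and higher numbers for higher permeability:
compound 1 `C=C(C)C(=O)N1CCC(CN(C2Cc3cc(C#N)ccc3N(Cc3cncn3C)C2)S(=O)(=O)c2ccccn2)CC1` gives 0.5 10^-6 cm/s;
compound 2 `Cn1cncc1CN1CC(N(CC2CCN(C(=O)OC(C)(C)C)CC2)S(=O)(=O)c2ccccn2)Cc2cc(C#N)ccc21` gives 15.5 10^-6 cm/s;
compound 3 `Cn1cncc1CN1CC(N(CCn2cccc2)S(=O)(=O)c2ccccn2)Cc2cc(C#N)ccc21` gives 12.4 10^-6 cm/s.

Compound 2 stands highest of the three numbers; compound 3 lies within the scatter of it, while compound 1 lies far lower, as shown by a 31-fold higher number from compound 1 to compound 2 (1.49 log units; beyond the scatter). Compound 4 `Cn1cnc(S(=O)(=O)N2CCC(CN(C3Cc4cc(C#N)ccc4N(Cc4cncn4C)C3)S(=O)(=O)c3ccccn3)CC2)c1` differs from compound 2 in one place: (1-methyl-1H-imidazol-4-yl)sulfonyl in place of tert-butoxycarbonyl on an amine nitrogen in a ring. Going by the values given here, two measured steps touch the same part of the shared core, a 31-fold higher number from compound 1 to compound 2 (1.49 log units; beyond the scatter) and a 25-fold higher number from compound 1 to compound 3 (1.39 log units; beyond the scatter), both large, both rising from compound 1. Among the compounds with values here, no measured compound carries a sulfonyl on an amine nitrogen in a ring, so the size of the new step is open. A step downward is expected for compound 4, a 3.9-fold lower number from compound 2 to compound 4 (0.59 log units; beyond the scatter), since compound 1 gives 0.5 10^-6 cm/s. For compound 4 an estimated 4 10^-6 cm/s is expected, between 1.2 10^-6 cm/s and 12 10^-6 cm/s.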

Compound 4, apparent permeability: 0.1 10^-6 cm/s
Compound 4: middle estimate off by 40-fold (1.60 log units), on the high side, and the stated range ends above it.
By their numbers in this assay, from the lowest: compound 4; then compound 1; then compounds 3 and 2 (each within the scatter of the next).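

Going by these compounds alone, at the amine nitrogen in a ring, the earlier compounds carried only carbonyl-linked groups, and the sulfonyl-linked group now gives a 160-fold lower number from compound 2 to compound 4 (2.19 log units; beyond the scatter) against tert-butoxycarbonyl and a 5.0-fold lower number from compound 1 to compound 4 (0.70 log units; beyond the scatter) against (1-methylethenyl)carbonyl. Both steps fall, though they differ in size, and compound 4 replaces compound 1 as the lowest of the series in this assay. Nothing at hand gives a reason for either step.

Going by these compounds, whether a free ring amine or a methylsulfonyl group would sit with compound 4 or with compound 2 stays open. Also open, on these data alone, is whether the sulfonyl or the five-membered aromatic ring goes with the fall.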